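From ethoxy to hydroxy at the assay limit

The source may report more compounds than this note shows. Statements on the series, on what has been measured and on what is new or still open speak of the compounds shown alone.

In an ADME assay on L1210/0 cells (Mus musculus) for cytotoxicity, with a stated time of 48 h (a higher number here means a weaker inhibitor, a lower number a stronger inhibitor), compound 3 (`CCOc1ncnc2c1ncn2C[C@@H]1C[C@H](CO)c2ccccc21`) gives > 200000 nM as a limit and not a number. Compound 1 (`OC[C@H]1C[C@@H](Cn2cnc3c(NC4CC4)ncnc32)c2ccccc21`) gives > 200000 nM as a limit too. Compound 2 (`Nc1ncnc2c1ncn2C[C@@H]1C[C@H](CO)c2ccccc21`) likewise gives > 200000 nM as a limit. All three rest on the limit of > 200000 nM in this assay, at which 3 of the 3 values shown sit, and none stands apart. Compound 4 (`OC[C@H]1C[C@@H](Cn2cnc3c(O)ncnc32)c2ccccc21`) carries hydrogen in place of ethyl on an oxygen on an aromatic ring. Within the data shown here, the steps that bear on it are a step that the two limits leave unreadable from compound 2 to compound 3 and a step that the two limits leave unreadable from compound 1 to compound 3 and also a step that the two limits leave unreadable from compound 1 to compound 2 and none of them gives a size. No step beyond the scatter is therefore expected in this assay and no direction is expected either. The estimated step is a number no higher from compound 3 to compound 4 (the limit leaves the size open) and another limit is likely. For compound 4 the estimated value is 200000 nM (expected range 120000 nM to 300000 nM).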

Compound 4, half-maximal inhibitory concentration: > 200000 nM
Compound 4 was reported as a limit; the forecaster's own chance of this, stated with the estimate: 90%; the middle value sits exactly at the limit.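

In this assay compound 4 gives > 200000 nM, which is a limit and not a number. Among these compounds, no step among compound 1, compound 2, compound 3 and compound 4 can be read. The compounds shown leave open how these four compare in this read-out, since all rest on one limit: the limit of > 200000 nM in this assay, at which 4 of the 4 values shown sit.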